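Swapping a Side Chain for a Ring in Compound 4

This account rests on a few compounds, and the source may have more. Where it says the series, first, only, none or still open, it means among the compounds named here.

Compound 1 `COC(=O)/C=C/c1cccc(N(Cc2ccc(-c3cccc(Cl)c3)cc2)C(=O)C2CCCCC2)c1` gives 94 nM in an assay on isolated protein with Bile acid receptor (Homo sapiens) as the target; on this read-out higher numbers stand for an effect only at larger amounts of compound and lower numbers for an effect already at smaller amounts.
Compound 2 `COC(=O)/C=C/c1cccc(N(Cc2ccc(C(C)(C)C)cc2)C(=O)C2CCCCC2)c1` gives > 1000 nM in this assay, which is a limit of the assay rather than a number.
Compound 3 `COC(=O)/C=C/c1cccc(N(Cc2ccc(/C=C/C(=O)N(C)C)cc2)C(=O)C2CCCCC2)c1` gives > 1000 nM in this assay, again only a limit.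

Compound 3 therefore sits at the limit of > 1000 nM in this assay, at which 2 of the 3 values shown sit, sharing that position with compound 2, so its true value is not known. Compound 4 `COC(=O)/C=C/c1cccc(N(Cc2ccc(-c3cccc(C(C)=O)c3)cc2)C(=O)C2CCCCC2)c1` differs from compound 3 in one place: 3-acetylphenyl in place of 2-(dimethylcarbamoyl)ethenyl on an aromatic carbon. The measured steps that bear on this are those leading to the two limits. From compound 1 to compound 3 the step was an at least 10-fold higher number from compound 1 to compound 3 (1.02 log units; beyond the scatter), and from compound 1 to compound 2 it was an at least 10-fold higher number from compound 1 to compound 2 (1.02 log units; beyond the scatter). Between compound 2 and compound 3 the step is a step that the two limits leave unreadable from compound 2 to compound 3. Compound 1 carries a 3-chlorophenyl group at the same place, and compound 4 brings back a ring of the same kind, 3-acetylphenyl, in place of the chain. The change from compound 3 to compound 4 is thus expected to reverse much of the step seen from compound 1 to compound 3, giving a large lowering in this assay, estimated as an at least 5.0-fold lower number from compound 3 to compound 4 (0.69 log units; beyond the scatter). Compound 4 is expected to reach about 200 nM, within a range from 60 nM to 800 nM.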

Compound 4, half-maximal effective concentration: 227 nM
For compound 4 the middle estimate is 1.1-fold (0.05 log units) below the measured one, and the stated range covers the measured number.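

In this assay, a 3-acetylphenyl group at this position gives a readable value where neither non-ring group did, with an at least 4.4-fold lower number from compound 3 to compound 4 (0.64 log units; beyond the scatter) and an at least 4.4-fold lower number from compound 2 to compound 4 (0.64 log units; beyond the scatter). Until now, 3-chlorophenyl was the only ring shown here, and compound 4 shows that a second ring with a different group on it also keeps a readable value, although what that ring carries still matters: acetyl in place of chloro gives a 2.4-fold higher number from compound 1 to compound 4 (0.38 log units; beyond the scatter). Compound 2 and compound 3 each stand at a limit of the assay rather than at a number, so the two steps from them give only a minimum size and the step between them cannot be read: the limit of > 1000 nM in this assay, at which 2 of the 4 values shown sit.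

Going by these compounds alone, with only two ring-bearing compounds, these results cannot separate the contribution of the ring itself from that of the group it carries, and a plain phenyl ring would help to make that distinction. On these data alone, it also remains open how an amine or a carboxylic acid in place of the acetyl would compare with the chloro and acetyl groups.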